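Butoxy to diethylamino on the shared core

This account rests on a few compounds, and the source may have more. Where it says the series, first, only, none or still open, it means among the compounds named here.

Values in a functional assay on HeLa cells (Homo sapiens) for antiproliferative activity, read by WST assay, with a stated time of 24 h; a lower number here means a stronger inhibitor, a higher number a weaker inhibitor:
- compound 1 `C=C[C@]1(C)CC[C@@H](C(=C)COCC)C[C@H]1C(=C)C`: 106000 nM
- compound 2 `C=C[C@]1(C)CC[C@@H](C(=C)COCCCC)C[C@H]1C(=C)C`: 266000 nM
- compound 3 `C=C[C@]1(C)CC[C@@H](C(=C)CN(CC)CC)C[C@H]1C(=C)C`: not yet measured

In this assay compound 2 holds the higher number of the pair, at 266000 nM. The next change puts diethylamino in place of butoxy on a saturated chain carbon bound to a double-bonded chain carbon. For the measured compounds named here, the only measured step, a 2.5-fold higher number from compound 1 to compound 2 (0.40 log units; beyond the scatter), is modest and alters the ether chain, so it bears only indirectly, and no measured pair makes this exchange. A modest move to a lower number is expected, as the estimated step of a 2.7-fold lower number from compound 2 to compound 3 (0.42 log units; beyond the scatter). The estimate for compound 3 is 100000 nM, with an expected range of 30000 nM to 300000 nM.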

Compound 3, half-maximal inhibitory concentration: 14400 nM
Estimate against measurement, compound 3: 6.9-fold (0.84 log units) above, and the stated range ends above it.
By their numbers in this assay, from the lowest: compound 3; then compound 1; then compound 2.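

In this assay, the exchange on a saturated chain carbon bound to a double-bonded chain carbon gives a larger step than the ether change did: diethylamino in place of butoxy gives an 18-fold lower number from compound 2 to compound 3 (1.27 log units; beyond the scatter). Diethylamino in place of ethoxy points the same way, with a 7.4-fold lower number from compound 1 to compound 3 (0.87 log units; beyond the scatter), so the lower number holds against both ethers shown. No measurement on hand accounts for this shift.

As far as these compounds go, whether the step follows the nitrogen itself or its ethyl groups stays open. A primary amine or dibutylamino at this place would bear on that.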